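The compounds below may be only part of what the source reports. "The series", "measured", "known", "first", "only" and "open" are said of these compounds alone.

Measured so far in a functional assay on HepG2 cells (Homo sapiens) for antiproliferative activity, read by CCK-8 assay, with a stated time of 48 h; a lower number here means a stronger inhibitor, a higher number a weaker inhibitor: compound 1 `CNC(=O)c1cc(Oc2ccc(/C=C/c3ccccn3)cc2)ccn1` gives 21600 nM. Compound 2 `O=C(NCc1ccccc1)c1cc(Oc2ccc(/C=C/c3ccccn3)cc2)ccn1` gives 27900 nM. Compound 3 `CC(C)NC(=O)c1cc(Oc2ccc(/C=C/c3ccccn3)cc2)ccn1` gives only > 100000 nM, which is a limit of the assay and not a number.

Compound 1 holds the lowest of the two numbers in this assay, with a 1.3-fold higher number from compound 1 to compound 2 (0.11 log units; within the scatter). Compound 4 `O=C(NC1CC1)c1cc(Oc2ccc(/C=C/c3ccccn3)cc2)ccn1` differs from compound 1 by cyclopropyl in place of methyl on an amide-type nitrogen. The step that bears most on it is an at least 4.6-fold higher number from compound 1 to compound 3 (0.66 log units; beyond the scatter), and an at least 3.5-fold higher number from compound 2 to compound 3 (0.55 log units; beyond the scatter) points the same way, both set by the limit of > 100000 nM in this assay, at which 1 of the 3 values shown sits. Enlarging the group on the amide nitrogen has so far given higher numbers, so compound 4 is expected to show a 2.1-fold higher number from compound 1 to compound 4 (0.32 log units; beyond the scatter), a modest rise. Compound 4 is estimated at 45000 nM, in the range 18000 nM to 100000 nM.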

Compound 4, half-maximal inhibitory concentration: 31000 nM
Compound 4: middle estimate off by 1.5-fold (0.16 log units), on the high side; the range from low to high includes it.
By their numbers in this assay, from the lowest: compounds 1, 2 and 4 (each within the scatter of the next). At a limit, above all of these: compound 3.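

Cyclopropyl on the amide-type nitrogen stands level with both methyl and benzyl in this assay, with a 1.4-fold higher number from compound 1 to compound 4 (0.16 log units; within the scatter) and a 1.1-fold higher number from compound 2 to compound 4 (0.05 log units; within the scatter). Isopropyl alone departs from these three groups, with an at least 3.2-fold lower number from compound 3 to compound 4 (0.50 log units; beyond the scatter), so a larger group at this position does not by itself bring a higher number. That step rests on a limit and not a number: the limit of > 100000 nM in this assay, at which 1 of the 4 values shown sits.

Still open, as far as these compounds go, is whether an amine, a carboxylic acid or a longer chain on this nitrogen would stay level with methyl, benzyl and cyclopropyl or move away from them.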